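The source may report more compounds than this note shows. Statements on the series, on what has been measured and on what is new or still open speak of the compounds shown alone.

Compound 1 `Cc1nc(C)c(CN2CCN(c3cccc4[nH]c(-c5ccc(C(C)(C)C)cc5)nc34)CC2)s1` gives 27 nM in an assay on isolated protein for displacement of a labelled ligand from Gonadotropin-releasing hormone receptor (Homo sapiens); a lower number here means a stronger inhibitor, a higher number a weaker inhibitor. Compound 2 `CCCCn1cnc(CN2CCN(c3cccc4[nH]c(-c5ccc(C(C)(C)C)cc5)nc34)CC2)c1C` gives 46 nM.

Within the data shown here, compound 2 holds the highest of the two numbers, though its only neighbour is compound 1, reached by the step of a 1.7-fold higher number from compound 1 to compound 2 (0.23 log units; within the scatter), which stays within the scatter. Compound 3 `CCCn1c(CC)nc(C)c1CN1CCN(c2cccc3[nH]c(-c4ccc(C(C)(C)C)cc4)nc23)CC1` differs from compound 2 by 2-ethyl-4-methyl-1-propyl-1H-imidazol-5-yl in place of 1-butyl-5-methyl-1H-imidazol-4-yl on a saturated chain carbon bound to an amine nitrogen in a ring. Among the measured compounds shown here, the one measured step that bears on a swap of this five-membered ring, from compound 1 to compound 2, was small, so the expected step of a 1.2-fold lower number from compound 2 to compound 3 (0.06 log units; within the scatter) is none beyond the scatter. Compound 3 is therefore expected to give about 40 nM, between 15 nM and 120 nM.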

Compound 3, half-maximal inhibitory concentration: 57 nM
Estimate against measurement, compound 3: 1.4-fold (0.15 log units) below; the range from low to high includes it.
By their numbers in this assay, from the lowest: compounds 1, 2 and 3 (each within the scatter of the next, the first and the last beyond it).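

In this assay, replacing 1-butyl-5-methyl-1H-imidazol-4-yl with 2-ethyl-4-methyl-1-propyl-1H-imidazol-5-yl leaves the number within the scatter (a 1.2-fold higher number from compound 2 to compound 3 (0.09 log units; within the scatter)), so this position accepts both imidazoles alike. Against 2,4-dimethyl-1,3-thiazol-5-yl, the same imidazole gives the only step here beyond the scatter, and a modest one (a 2.1-fold higher number from compound 1 to compound 3 (0.32 log units; beyond the scatter)). Nothing given here explains either step.

As far as these compounds go, whether a phenyl or a pyridin-3-yl group on this saturated chain carbon would hold the number stays open. So does the effect of an amine or a hydroxyl on the propyl chain.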